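Adding a chain double bond to compound 1

The compounds below may be only part of what the source reports. "The series", "measured", "known", "first", "only" and "open" are said of these compounds alone.

In a functional assay on MDA-MB-231 cells (Homo sapiens) for antiproliferative activity, read by MTT assay (a higher number here means a weaker inhibitor, a lower number a stronger inhibitor), the measured compounds stand as follows
compound 1 `CCCCC/C=C\C/C=C\CCCCCCCc1cc(=O)c2c(O)c(C)c(OCOC)c(C)c2o1` gives 16100 nM
compound 2 `CCCC/C=C\CCCCCCCCCc1cc(=O)c2c(O)c(C)c(OCOC)cc2o1` gives > 87000 nM as a limit, not a number
compound 3 `CC/C=C\C/C=C\C/C=C\CCCCCCCc1cc(=O)c2c(O)cc(OCOC)cc2o1` gives 6790 nM

Compound 1 with 16100 nM is the higher of the two true numbers, and compound 3 with 6790 nM lies lower, beyond the usual scatter.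

Compound 4 `CC/C=C\C/C=C\C/C=C\CCCCCCCc1cc(=O)c2c(O)c(C)c(OCOC)c(C)c2o1` has but-1-en-1-yl in place of butyl on a saturated chain carbon bound to a double-bonded chain carbon. Within the data shown here, no measured pair isolates this change. Compound 4 shares its chain with compound 3 at 6790 nM in this assay and so a small step to a lower number is expected, possibly not beyond the scatter (a 1.6-fold lower number from compound 1 to compound 4 (0.21 log units; within the scatter)). Compound 4 is estimated at 10000 nM (expected range 4000 nM to 28000 nM).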

Compound 4, half-maximal inhibitory concentration: 16100 nM
Compound 4: middle estimate off by 1.6-fold (0.21 log units), on the low side; measured number inside the range.
By their numbers in this assay, from the lowest: compound 3; then compounds 1 and 4 (each within the scatter of the next). At a limit, above all of these: compound 2.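

In this assay, but-1-en-1-yl in place of butyl on a saturated chain carbon bound to a double-bonded chain carbon gives no change at the digits printed from compound 1 to compound 4 (within the scatter). Among these compounds, this is the first step that can be read at this position, and the extra chain double bond does not tell the two chains apart on this core. Nothing measured here bears on the reason for this flat step. Still open, from the compounds shown here alone, is whether a longer chain, or a carboxylic acid or an amine at the chain end, would shift the number at this position.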